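The source may hold more compounds than are shown below. What is called first, only, known or untested is meant among the compounds shown, and "the series" means these compounds.

Measured in an ADME assay on CEM-SS cells (Homo sapiens) for cytotoxicity, read by XTT assay (a higher number here means that more compound is tolerated, a lower number that less compound is tolerated), each value a limit:
- compound 1 `CN(O)C(=O)c1cc2c(CN3CCNC(=O)C3)cn(Cc3ccc(F)cc3)c2cn1`: > 100000 nM
- compound 2 `CN(O)C(=O)c1cc2c(CO)cn(Cc3ccc(F)cc3)c2cn1`: > 266000 nM
- compound 3 `COCCOCc1cn(Cc2ccc(F)cc2)c2cnc(C(=O)N(C)O)cc12`: > 100000 nM

Compound 1 stands at the limit of > 100000 nM in this assay, at which 2 of the 3 values shown sit, so it has no exact number. Compound 4 `CN(O)C(=O)c1cc2c(C(=O)N3CCC[C@@H]3CO)cn(Cc3ccc(F)cc3)c2cn1` carries (2-(hydroxymethyl)pyrrolidin-1-yl)carbonyl in place of the (3-oxopiperazin-1-yl)methyl of compound 1 on an aromatic carbon ((2-(hydroxymethyl)pyrrolidin-1-yl)carbonyl in place of (3-oxopiperazin-1-yl)methyl on an aromatic carbon). Two measured changes to that same group bear on this: a step that the two limits leave unreadable from compound 1 to compound 2 and a step that the two limits leave unreadable from compound 1 to compound 3. Neither gives a size to carry over, and neither points in a direction. All three compounds are tolerated up to their limits, so no step beyond the usual scatter is expected in this assay. The expected change is a number no higher from compound 1 to compound 4 (the limit leaves the size open). For compound 4 the estimated value is 100000 nM, with an expected range of 30000 nM to 270000 nM, and it may well be reported only as a limit.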

Compound 4, half-maximal cytotoxic concentration: > 32000 nM
Compound 4 was reported as a limit; the forecaster's own chance of this, stated with the estimate: 85%; the middle value does not contradict the limit.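

Compound 4 is reported only as a limit, as are compounds 1, 2 and 3, so no step among these compounds can be read. The compounds shown leave open where the actual cytotoxic concentration of each one lies.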